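The source may hold more compounds than are shown below. What is called first, only, known or untested is meant among the compounds shown, and "the series" means these compounds.

Working notes on the series in a functional assay on HCT-116 cells (Homo sapiens) for antiproliferative activity, read by CCK-8 assay, with a stated time of 72 h, tested at 8 uM; on this read-out lower numbers stand for a weaker effect and higher numbers for a stronger effect at the one concentration tested. Compound 1 `Nc1ccccc1NC(=O)/C=C/c1ccc(Cn2cnc3c(Nc4ccccc4)nc(Cl)nc32)cc1` gives 30.9% in this assay, compound 2 `Nc1ccccc1NC(=O)c1ccc(CNc2nc(Cl)nc3c2ncn3Cc2ccccc2)cc1` gives 11.5%, and compound 3 `CCC(C)n1cnc2c(NCc3ccc(C(=O)Nc4ccccc4N)cc3)nc(Cl)nc21` gives 75.1%. Compound 3 stands highest of the three numbers, beyond the scatter of both others; compound 1 is the nearer of the two and compound 2 the further. For the measured compounds named here, the only step between compounds that differ in one place is a number 63.6 percentage points higher from compound 2 to compound 3 (beyond the scatter), for sec-butyl in place of benzyl on an aromatic nitrogen, so the group on this nitrogen carries a large part of the read-out.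

Compound 4 `Nc1ccccc1NC(=O)c1ccc(CNc2nc(Cl)nc3c2ncn3C2CCCC2)cc1` has not yet been measured and differs from compound 3 by cyclopentyl in place of sec-butyl on an aromatic nitrogen. Going by the values given here, the step from compound 2 to compound 3 bears on the same position, but it swapped a group with an aromatic ring for one without; here neither sec-butyl nor cyclopentyl carries an aromatic ring, and no measured step compares the two. The change is therefore expected to give no step beyond the scatter, or at most a small one, in this assay. Compound 4 is estimated at 72%, with a range of 52% to 88%. The expected step is a number 3.1 percentage points lower from compound 3 to compound 4 (within the scatter).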

Compound 4, a percentage reported as inhibition, at one concentration (the size of the read-out at that concentration, not a potency): 80.6%
Beside the measured number, compound 4's estimate is 8.6 percentage points below it, and the stated range covers the measured number.
By their numbers in this assay, from the lowest: compound 2; then compound 1; then compounds 3 and 4 (each within the scatter of the next).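

In this assay, cyclopentyl in place of sec-butyl on the aromatic nitrogen gives a number 5.5 percentage points higher from compound 3 to compound 4 (within the scatter), so a five-membered non-aromatic ring of carbon only and an open branched group cannot be told apart at this position. Cyclopentyl in place of benzyl gives a number 69.1 percentage points higher from compound 2 to compound 4 (beyond the scatter), which shows that the large gain over benzyl is not confined to sec-butyl but is shared by a second group without an aromatic ring. Nothing available on these compounds bears on why this position responds in this way.

On these data alone, whether a longer chain, a small group such as methyl, or an amine or carboxylic acid on this nitrogen would hold the read-out remains open. With only one concentration tested, these numbers also leave the potency of compound 3 and compound 4 open.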